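Amide series: propylamino for bromo on the core

A few compounds are considered here, and "the series" means these few. Any claim that something is new, unique, unknown or untested is made for them only; others in the source may bear on it.

Measured so far:
compound 1 `C=CCOc1ccc(C(=O)Nc2cccc(Br)n2)cc1`, 65500 nM
compound 2 `CCCOc1ccc(C(=O)Nc2cccc(Br)n2)cc1`, > 100000 nM
compound 3 `CCCOc1ccc(C(=O)Nc2cnccn2)cc1`, 22500 nM

In an in vitro assay on HEK-tsA201 cells for antagonist activity at Neuronal acetylcholine receptor; alpha3/beta4 (Homo sapiens), read by fluorescence and calcium flux (on this read-out lower numbers stand for stronger inhibition and higher numbers for weaker inhibition), compound 2 reaches only the assay limit, > 100000 nM, so no number stands for it; this is the same limit noted as the limit of > 100000 nM in this assay, at which 1 of the 3 values shown sits. Compound 1 gives 65500 nM in this assay, and the step of an at least 1.5-fold higher number from compound 1 to compound 2 (0.18 log units; that floor lies within the scatter) is the only one measured so far. Compound 3 gives 22500 nM, but it differs from compound 2 in more than one place, so the two values are only set side by side here.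

Compound 4 `CCCNc1cccc(NC(=O)c2ccc(OCCC)cc2)n1` is not yet measured. It differs from compound 2 as propylamino in place of bromo on an aromatic carbon. Within the data shown here, no measured step touches this position or this kind of group, so the single step at the chain oxygen gives no guide to its size or direction. With compound 2 at a limit and nothing to carry over, the expectation for compound 4 is wide and leans toward another limit. The step from compound 2 to compound 4 is expected to be an at least 1.4-fold lower number from compound 2 to compound 4 (0.15 log units; that floor lies within the scatter) in this assay. Compound 4 is thus estimated at 70000 nM, within 15000 nM to 300000 nM.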

Compound 4, half-maximal inhibitory concentration: 12600 nM
Compound 4: middle estimate off by 5.6-fold (0.74 log units), on the high side; measured number outside the range, below it.
By their numbers in this assay, from the lowest: compounds 4 and 3 (each within the scatter of the next); then compound 1. At a limit, above all of these: compound 2.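

In this assay, the place that holds bromo proves responsive to substitution, with propylamino in place of bromo giving an at least 7.9-fold lower number from compound 2 to compound 4 (0.89 log units; beyond the scatter). Compound 2 stands at a limit, and the size of this step is a floor only: the limit of > 100000 nM in this assay, at which 1 of the 4 values shown sits. Unlike the earlier change at the chain oxygen, whose floor lies within the scatter, this change on an aromatic carbon next to the ring nitrogen gives a step beyond the scatter, and what enters carries a hydrogen-bond donor and a hydrogen-bond acceptor that bromo lacks.

The compounds shown do not separate the contribution of the amine nitrogen from that of the propyl chain, which an unsubstituted amine, a dimethylamino group or a longer chain at this place could address. Going by these compounds, whether propylamino gives a step of like size on the core of compound 1 also stays open.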